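The source may report more compounds than this note shows. Statements on the series, on what has been measured and on what is new or still open speak of the compounds shown alone.

Compound 1 `Cc1cc2ccccc2nc1-c1cn(-c2ccc(F)cc2)nn1` was examined in a functional assay on THP-1 cells (Homo sapiens) for cytotoxicity, read by MTT assay, with a stated time of 24 h; a lower number here means a stronger inhibitor, a higher number a weaker inhibitor. In this assay compound 1 gives only the limit of > 100 ug/mL, a limit rather than a number. Compound 3 `CCc1cc2ccccc2nc1-c1cn(CCC(F)(F)C(F)(F)C(F)(F)C(F)(F)C(F)(F)C(F)(F)C(F)(F)C(F)(F)F)nn1` likewise gives only the limit of > 100 ug/mL. Compound 2 `CCCCCCCCCCn1cc(-c2nc3ccccc3cc2CC)nn1` gives 34.3 ug/mL. Compound 1 therefore stands at the limit, where two of the three values shown sit (the limit of > 100 ug/mL in this assay, at which 2 of the 3 values shown sit). Compound 4 `CCCCc1cc2ccccc2nc1-c1cn(-c2ccc(F)cc2)nn1` differs from compound 1 by propyl in place of hydrogen on a saturated chain carbon bound to an aromatic carbon. Going by the values given here, no two measured compounds differ in a single place, so no measured step guides this change. Given that compound 1 sits at the limit (the limit of > 100 ug/mL in this assay, at which 2 of the 3 values shown sit), the step from compound 1 to compound 4 an at least 1.1-fold lower number from compound 1 to compound 4 (0.04 log units; that floor lies within the scatter) is expected to be small, in either direction or none beyond the scatter. Compound 4 is estimated to give about 90 ug/mL, between 30 ug/mL and 300 ug/mL, with a fair chance that only a limit is reported.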

Compound 4, half-maximal inhibitory concentration: 78.3 ug/mL
The estimate for compound 4 lay 1.1-fold (0.06 log units) above the measured number; the range from low to high includes it.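

In this assay, propyl in place of hydrogen on a saturated chain carbon bound to an aromatic carbon gives an at least 1.2-fold lower number from compound 1 to compound 4 (0.10 log units; that floor lies within the scatter). Compound 4 thus gives a number, 78.3 ug/mL, where the compound without this change gave none. Compound 1 gives only a limit, so the step is a floor and not a size: the limit of > 100 ug/mL in this assay, at which 2 of the 4 values shown sit.

The compounds shown leave open how large the true step is. They also leave open whether a longer chain, an amine or a carboxylic acid at this place would carry the number beyond the scatter.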